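Series notes: thiophen-2-yl replacing 4-chlorophenyl on compound 3

The source may report more compounds than this note shows. Statements on the series, on what has been measured and on what is new or still open speak of the compounds shown alone.

Three compounds on a shared core have numbers in a functional assay on NCI-H522 cells (Homo sapiens) for inhibition, read by sulforhodamine B assay, with a stated time of 48 h, tested at 10 uM; a lower number here means less inhibition, a higher number more inhibition at the concentration tested (going by the name of the read-out). Compound 1 `Brc1cn2ccnc2c(-c2ccc3ncn(C4CCCCC4)c3c2)n1` gives 16.2%. Compound 2 `c1cn2cc(-c3ccsc3)nc(-c3ccc4ncn(C5CCCCC5)c4c3)c2n1` gives 10.3% in this assay. Compound 3 `Clc1ccc(-c2cn3ccnc3c(-c3ccc4ncn(C5CCCCC5)c4c3)n2)cc1` gives 19.8% in this assay, the highest of the three numbers, though both of its gaps lie within the scatter: a number 3.6 percentage points higher from compound 1 to compound 3 (within the scatter) and a number 9.5 percentage points higher from compound 2 to compound 3 (within the scatter). The remaining step, a number 5.9 percentage points lower from compound 1 to compound 2 (within the scatter), is also within the scatter, so none of the three numbers can be ordered against another.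

Compound 4 `c1csc(-c2cn3ccnc3c(-c3ccc4ncn(C5CCCCC5)c4c3)n2)c1` is not yet measured. It differs from compound 3 in one place: thiophen-2-yl in place of 4-chlorophenyl on an aromatic carbon. The measured step that bears most directly on this change is a number 9.5 percentage points higher from compound 2 to compound 3 (within the scatter), in which thiophen-3-yl was exchanged for 4-chlorophenyl; the present change runs the other way, from 4-chlorophenyl to a thiophene, here thiophen-2-yl. A loss of roughly that size, or no movement beyond the scatter, is the natural expectation. The step of a number 7.8 percentage points lower from compound 3 to compound 4 (within the scatter) is therefore the expected outcome. Compound 4 is estimated at 12% in this assay, with a range from 2% to 24%.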

Compound 4, a percentage reported as inhibition, at one concentration (the size of the read-out at that concentration, not a potency): 13.2%
Compound 4: the middle estimate sits 1.2 percentage points below what was measured, within the range that was stated.
By their numbers in this assay, from the lowest: compounds 2, 4, 1 and 3 (each within the scatter of the next).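

Within the data shown here, with compound 4 included, this assay covers four groups on the same aromatic carbon of the shared core, and the new comparisons give a number 6.6 percentage points lower from compound 3 to compound 4 (within the scatter) and a number 2.9 percentage points higher from compound 2 to compound 4 (within the scatter) and a number 3 percentage points lower from compound 1 to compound 4 (within the scatter) with no pair separated by more than the scatter. Moving the thiophene attachment from thiophen-3-yl to thiophen-2-yl therefore does not separate these two compounds, and neither does replacing the six-membered carbon ring of 4-chlorophenyl with the five-membered ring of thiophen-2-yl or replacing bromo with thiophen-2-yl. No supporting measurement is available to explain these numbers.

From the compounds shown here alone, it remains open whether an amine, a carboxylic acid or a longer alkyl chain at this aromatic carbon would give a number that stands clear of the scatter from the four groups seen here. Going by these compounds, the readings come from a single concentration and do not express potency, so any difference in potency among compounds 1 to 4 also remains open.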